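The compounds below may be only part of what the source reports. "The series", "measured", "known", "first", "only" and "open" are said of these compounds alone.

Measured compounds:
- Compound 1, `CCOC(=O)/C(O)=C/C(=O)c1cn(Cc2ccc(F)c(F)c2)c2cccc(OC)c12` — in an ADME assay on MT4 cells (Homo sapiens) for cytotoxicity, read by MTT assay (a higher number here means that more compound is tolerated, a lower number that less compound is tolerated), compound 1 gives 125000 nM
- Compound 2, `COc1cccc2c1c(C(=O)/C=C(\O)C(=O)O)cn2Cc1cccc(F)c1F` — in this assay compound 2 gives 17500 nM

Among the measured compounds shown here, compound 2 stands lowest of the two numbers; compound 1, its only neighbour, sits a clear distance above it, beyond the scatter. Compound 3, `CCOC(=O)/C(O)=C/C(=O)c1cn(Cc2cccc(F)c2F)c2cccc(OC)c12`, is not yet measured. It comes from compound 2 by a single change, (ethyl in place of hydrogen on an oxygen next to a carbonyl group). Compound 1 also carries the ethyl ester and gives 125000 nM, so the step from compound 2 to compound 3 is expected to go upward, though with two compounds that differ in more than one place this is a loose guide. For compound 3 the expected step is a 3.4-fold higher number from compound 2 to compound 3 (0.54 log units; beyond the scatter), giving an estimate of 60000 nM in this assay, with a range from 20000 nM to 150000 nM.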

Compound 3, half-maximal cytotoxic concentration: 21100 nM
Compound 3: the middle estimate sits 2.8-fold (0.45 log units) above what was measured, and the stated range covers the measured number.
By their numbers in this assay, from the lowest: compounds 2 and 3 (each within the scatter of the next); then compound 1.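

The change from carboxy to ethoxycarbonyl gives a 1.2-fold higher number from compound 2 to compound 3 (0.08 log units; within the scatter) in this assay and so makes no measurable difference while the 2,3-difluorophenyl group is present. With the ethyl ester held fixed, 2,3-difluorophenyl in place of 3,4-difluorophenyl gives a 5.9-fold lower number from compound 1 to compound 3 (0.77 log units; beyond the scatter) and so, among these compounds, the clear difference goes with the difluorophenyl group and not with the ester. Going by these compounds, whether an amide or a longer chain in place of the ethyl would also leave the number unmoved stays open, as does the effect of the same ester change with 3,4-difluorophenyl. Nothing available explains either step.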